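The source may hold more compounds than are shown below. What is called first, only, known or untested is meant among the compounds shown, and "the series" means these compounds.

Compound 1 `CCOC(=O)c1sc(-c2cccc(NC(=O)c3ccccc3)c2)nc1Nc1ccc(N2CCN(C)CC2)cc1` and compound 2 `CN1CCN(c2ccc(Nc3nc(-c4cccc(NC(=O)c5ccccc5)c4)sc3C(N)=O)cc2)CC1` share one core and differ at a single carbonyl carbon. In a functional assay on Ramos cells (Homo sapiens) for antiproliferative activity, read by CCK-8 assay, with a stated time of 72 h, tested at 40 uM (a higher number here means more inhibition at the concentration tested (going by the name of the read-out), a lower number less inhibition), compound 1 gives 77.1% and compound 2 gives 98.1%. Among the measured compounds shown here, the step of a number 21 percentage points higher from compound 1 to compound 2 (beyond the scatter) is the only measured change so far, with amino in place of ethoxy on a carbonyl carbon. Compound 2 thus stands highest of the two numbers, and compound 1 is the nearest, lower by that step, beyond the scatter.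

Compound 3 `CN1CCN(c2ccc(Nc3nc(-c4cccc(NC(=O)c5ccc(F)c(Cl)c5)c4)sc3C(N)=O)cc2)CC1` keeps the amide of compound 2 and alters the benzamido group: 3-chloro-4-fluorophenyl in place of phenyl on a carbonyl carbon. For the measured compounds named here, no measured step touches this phenyl; the one measured step sits on a different carbonyl carbon and gives no guide to the size of this change. Since compound 2 already reads 98.1%, little room remains upward, so the expected step of a number 5.1 percentage points lower from compound 2 to compound 3 (within the scatter) is none beyond the scatter. Compound 3 is expected at 93%, within 80% to 100%.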

Compound 3, a percentage reported as inhibition, at one concentration (the size of the read-out at that concentration, not a potency): 97.5%
For compound 3 the middle estimate is 4.5 percentage points below the measured one; low and high end bracket the measured number.
By their numbers in this assay, from the lowest: compound 1; then compounds 3 and 2 (each within the scatter of the next).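

Among the compounds shown here, on the carbonyl carbon of the benzamido group, the step of a number 0.6 percentage points lower from compound 2 to compound 3 (within the scatter) is the first measured change at this position in this assay; 3-chloro-4-fluorophenyl and phenyl cannot be told apart there. Both readings lie near the top of the percentage scale at a single concentration, and any difference in potency between the two groups stays unseen in them. No measured evidence on the reason for this result is at hand.

Open, from the compounds shown here alone, is whether a different group on this carbonyl carbon, such as a morpholine ring or a short alkyl chain in place of the phenyl, would hold the reading in this assay. Also open, going by these compounds, is whether 3-chloro-4-fluorophenyl would move the reading on the ethyl ester compound 1, at 77.1%, and whether lower test concentrations would separate compound 2 and compound 3.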